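Swapping the Halogenated Phenyl on a Cinnamamide Tail

The compounds below may be only part of what the source reports. "The series", "measured", "known", "first", "only" and "open" are said of these compounds alone.

Measured compounds:
- compound 1 `COc1ccc(/C=C/C(=O)Nc2cc3c(Nc4ccc(F)c(Cl)c4)ncnc3cc2OC)c(OC)c1`: "not determined" (no result reported)
- compound 2 `O=C(/C=C/c1cccc(Cl)c1Cl)Nc1cc2c(Nc3ccc(F)c(Cl)c3)ncnc2cc1O[C@H]1CCOC1`: 30500 nM
- compound 3 `COc1cc2ncnc(Nc3ccc(F)c(Cl)c3)c2cc1NC(=O)/C=C/c1ccc(C#N)cc1`: "not determined" (no result reported)

Three compounds share a common core and differ mainly in the aryl group at the end of the double-bonded chain. In a functional assay on HeLa cells (Homo sapiens) for cytotoxicity, read by MTT assay, with a stated time of 72 h (a higher number here means a weaker inhibitor, a lower number a stronger inhibitor), compound 2 gives 30500 nM, a weak effect. For the measured compounds named here, compound 2 stands as the only compound with a number in this assay; compound 1 is recorded as "not determined" (no result reported) and compound 3 as "not determined" (no result reported), so nothing can be said about how they compare with compound 2 or with each other.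

The step of interest leads to compound 4 `O=C(/C=C/c1ccc(Br)cc1)Nc1cc2c(Nc3ccc(F)c(Cl)c3)ncnc2cc1O[C@H]1CCOC1`, which differs from compound 2 in a single place:

4-bromophenyl in place of 2,3-dichlorophenyl on a double-bonded chain carbon bound to a double-bonded chain carbon

Going by the values given here, no step between two measured compounds is available to show how a change of this kind moves the numbers, and the scatter of repeated measurements in this assay is wide. The expectation is therefore that the step of a 1.1-fold lower number from compound 2 to compound 4 (0.04 log units; within the scatter) stays within the scatter, with no clear direction. Compound 4 is expected to give about 28000 nM in this assay, with a plausible range from 9000 nM to 85000 nM.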

Compound 4, half-maximal inhibitory concentration: 27500 nM
Estimate against measurement, compound 4: 1.0-fold (0.01 log units) above; measured number inside the range.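

For the compounds shown here, compound 2 and compound 4 form the first pair of measured compounds at this position, and in this assay the swap gives a 1.1-fold lower number from compound 2 to compound 4 (0.04 log units; within the scatter) and leaves the two compounds indistinguishable. The swap replaces 2,3-dichlorophenyl, with 8 heavy atoms, by 4-bromophenyl, with 7, on a double-bonded chain carbon bound to a double-bonded chain carbon, so the halogen element, the number of halogen atoms and their places on the ring all differ at once, yet the pair still cannot be told apart in this cell test. Nothing available here offers a reason for this result.

Both numbered compounds carry only halogen atoms on this ring, so the pair cannot say whether a phenyl group bearing an amine or a carboxylic acid would give a number clearly apart from theirs. It also leaves open what a longer chain in place of the double-bonded chain would do, and whether any change at this position can move the number beyond the scatter at all.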